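The source may hold more compounds than are shown below. What is called first, only, known or untested is meant among the compounds shown, and "the series" means these compounds.

Measured compounds in a functional assay on HepG2 cells (Homo sapiens) for cytotoxicity, read by MTT assay, with a stated time of 72 h; on this read-out lower numbers stand for stronger inhibition of growth and higher numbers for weaker inhibition of growth:

- compound 1, `CS/C(=N\C(=O)c1ccno1)NC(=O)c1ccno1`: > 100000 nM (a limit of the assay, not a number)
- compound 2, `C[Se]/C(=N\C(=O)c1ccno1)NC(=O)c1ccno1`: 9350 nM
- compound 3, `CS/C(=N\C(=O)c1cc(-c2ccccc2)nc2ccccc12)NC(=O)c1cc(-c2ccccc2)nc2ccccc12`: 48200 nM

Compound 1 is reported only at the limit of this assay, (the limit of > 100000 nM in this assay, at which 1 of the 3 values shown sits). Going by the values given here, the one counted change is a group of 2 heavy atoms (1 carbon, 1 selenium; no ring) in place of a group of 2 heavy atoms (1 carbon, 1 sulfur; no ring), on a carbon with a double bond to nitrogen, and it gives the step of an at least 10-fold lower number from compound 1 to compound 2 (1.02 log units; beyond the scatter). Compound 3 carries a different core; the difference between the core of compound 1 and the core of compound 3 is not broken down here. Compound 3 gives the highest number of the two that are numbers, and it sits at a beyond-scatter distance from compound 2.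

Compound 4, `C[Se]/C(=N\C(=O)c1cc(-c2ccccc2)nc2ccccc12)NC(=O)c1cc(-c2ccccc2)nc2ccccc12`, is not yet measured in this assay. It relates to compound 3 as compound 2 relates to compound 1: the change is a group of 2 heavy atoms (1 carbon, 1 selenium; no ring) in place of a group of 2 heavy atoms (1 carbon, 1 sulfur; no ring), on a carbon with a double bond to nitrogen, on the same place in both pairs, so it is the same change set on the core of compound 3. The expected step is an 8.0-fold lower number from compound 3 to compound 4 (0.90 log units; beyond the scatter). Among the compounds with values here, this rests on the single measured instance, the step of an at least 10-fold lower number from compound 1 to compound 2 (1.02 log units; beyond the scatter), which is at least as large as the scatter allows one to say, with the starting point a limit and not a number, so the true size of that step is not known. Compound 4 is therefore expected near 6000 nM, with a range from 1500 nM to 25000 nM to cover the uncertainty of carrying one step onto another core.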

Compound 4, concentration for total growth inhibition: 10100 nM
The estimate for compound 4 lay 1.7-fold (0.23 log units) below the measured number; low and high end bracket the measured number.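

In this assay, replacing methylsulfanyl with its selenium counterpart on the carbon with a double bond to nitrogen again gives a lower number, a 4.8-fold lower number from compound 3 to compound 4 (0.68 log units; beyond the scatter), so the direction of the change holds on both cores shown, though two cores make no general rule for the series. Set side by side, the two steps read: the same change on two cores in this assay, an at least 10-fold lower number (1.02 log units; beyond the scatter) from compound 1 to compound 2 and a 4.8-fold lower number (0.68 log units; beyond the scatter) from compound 3 to compound 4; the limit leaves it open whether they differ. Compound 1 is a limit of the assay and not a number, > 100000 nM, so the notes can record a shared direction but not a shared size.

The compounds shown leave open how the carbon with a double bond to nitrogen responds to anything other than these two groups, for instance a longer chain such as ethylsulfanyl, or an amine at the same place. They also leave open whether the direction of the change persists on a third core, and whether a pair with measured numbers at both ends would give a step closer to the one on the core of compound 3 or a different one.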